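A few compounds are considered here, and "the series" means these few. Any claim that something is new, unique, unknown or untested is made for them only; others in the source may bear on it.

In a functional assay (aorta) with Rattus norvegicus as the target, in the presence of a further agent that is not named here (on this read-out higher numbers stand for an effect only at larger amounts of compound and lower numbers for an effect already at smaller amounts), compound 2 `COC(=O)C1=C(C)N=C(C)/C(=C(/O)OC)C1c1cccc(OCc2c(C(N)=O)no[n+]2[O-])c1` gives 1200 nM, the higher of the two numbers, while compound 1 `COC(=O)C1=C(C)N=C(C)/C(=C(/O)OC)C1c1cccc(OCc2no[n+]([O-])c2C)c1` gives 500 nM. Compound 3 `COC(=O)C1=C(C)N=C(C)/C(=C(/O)OC)C1c1cccc(OCc2no[n+]([O-])c2C#N)c1` differs from compound 2 by a group of 8 heavy atoms (3 carbon, 3 nitrogen, 2 oxygen; one five-membered aromatic ring with 3 hetero atoms) in place of a group of 9 heavy atoms (3 carbon, 3 nitrogen, 3 oxygen; one five-membered aromatic ring with 3 hetero atoms), on a saturated chain carbon bound to an oxygen on an aromatic ring. Within the data shown here, the one measured step that bears on this change, a 2.4-fold higher number from compound 1 to compound 2 (0.38 log units; beyond the scatter), alters the same group and is modest but beyond the scatter. Among the measured compounds shown here, a step of similar size towards a lower number is therefore expected in this assay, although no measurement yet fixes its direction. The expected change is a 2.7-fold lower number from compound 2 to compound 3 (0.43 log units; beyond the scatter). Compound 3 is estimated at 450 nM, with an expected range of 100 nM to 1800 nM.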

Compound 3, half-maximal effective concentration: 3.3 nM
The estimate for compound 3 lay 140-fold (2.13 log units) above the measured number; the whole stated range lies above it.
By their numbers in this assay, from the lowest: compound 3; then compound 1; then compound 2.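

In this assay, the group on this saturated chain carbon proves far more decisive than the earlier modest step suggested: cyano in place of methyl gives a 150-fold lower number from compound 1 to compound 3 (2.18 log units; beyond the scatter), and the nitrile-bearing group in place of the amide-bearing one gives a 360-fold lower number from compound 2 to compound 3 (2.56 log units; beyond the scatter). Of the three compounds, only compound 3 reaches a low number, so the change is not a small adjustment at this position. Nothing available explains the size of these steps. As far as these compounds go, what a carboxylic acid or an ethyl ester in place of cyano would give remains open.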